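The compounds below may be only part of what the source reports. "The series", "measured", "known", "first", "only" and "open" are said of these compounds alone.

Working notes on the urea series sharing the core of compound 1 `CCCCCCCc1ccc(NC(=O)Nc2c(C(C)C)cccc2C(C)C)cc1`. In an assay on isolated protein for inhibition of acyl-CoA:cholesterol acyltransferase (Oryctolagus cuniculus) (a lower number here means a stronger inhibitor, a higher number a weaker inhibitor), compound 1 gives 19 nM. Compound 2 `Cc1ccc(NC(=O)Nc2c(C(C)C)cccc2C(C)C)cc1` gives 250 nM, and compound 3 `CCCCCCCCCCCc1ccc(NC(=O)Nc2c(C(C)C)cccc2C(C)C)cc1` gives 9 nM. Compound 1 thus stands second highest of the three numbers: a 2.1-fold lower number from compound 1 to compound 3 (0.32 log units; beyond the scatter), while a 13-fold higher number from compound 1 to compound 2 (1.12 log units; beyond the scatter). Within the measured set, a 28-fold lower number from compound 2 to compound 3 (1.44 log units; beyond the scatter), so the shorter the chain on the aromatic carbon, the higher the number, with no compound going against this.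

Compound 4 `CC(C)c1cccc(C(C)C)c1NC(=O)Nc1ccc(C(C)(C)C)cc1` has not yet been measured in this assay. Its change from compound 1 is tert-butyl in place of heptyl on an aromatic carbon. The relevant steps are the large loss when the chain is cut back from heptyl to methyl and the modest gain when it is extended to undecyl. A tert-butyl group carries more carbon than the methyl of compound 2 but less than the heptyl of compound 1, so a higher number than compound 1 is expected, smaller than the step to compound 2. The expected step is a 4.2-fold higher number from compound 1 to compound 4 (0.62 log units; beyond the scatter). Compound 4 is estimated at 80 nM, with a range from 30 nM to 250 nM.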

Compound 4, half-maximal inhibitory concentration: 168 nM
The estimate for compound 4 lay 2.1-fold (0.32 log units) below the measured number; the measured number falls inside the stated range.
By their numbers in this assay, from the lowest: compound 3; then compound 1; then compounds 4 and 2 (each within the scatter of the next).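

At this position, para to a large group, the change to tert-butyl in this assay gives no separation from the methyl of compound 2 (a 1.5-fold lower number from compound 2 to compound 4 (0.17 log units; within the scatter)), while the long chains stand well apart (an 8.8-fold higher number from compound 1 to compound 4 (0.95 log units; beyond the scatter); a 19-fold higher number from compound 3 to compound 4 (1.27 log units; beyond the scatter)). The earlier trend with chain length therefore does not extend to this branched group: compound 4 goes against any reading of the number from carbon count alone, since its tert-butyl carries more carbon than methyl yet does not separate from it. Nothing available explains this result.

Open, from the compounds shown here alone, is whether a straight butyl at this position would behave like tert-butyl or fall in line with the chain series, which would separate branching from chain length. Also open, going by these compounds, is how an amine or a carboxylic acid at the end of the heptyl chain would fare.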